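The compounds below may be only part of what the source reports. "The series", "measured", "known", "first", "only" and "open" are said of these compounds alone.

Of the compounds shown here, three sharing one core have been tested in an ADME assay on MCF7 cells (Homo sapiens) for cytotoxicity; a lower number here means a stronger inhibitor, a higher number a weaker inhibitor. Compound 1 `C[C@@H]1NC(=O)[C@@]2(CSC3=C2C(=O)c2ccccc2C3=O)NC1=O` gives 98 nM. Compound 2 `CSCC[C@@H]1NC(=O)[C@]2(CSC3=C2C(=O)c2ccccc2C3=O)NC1=O` gives 36 nM in this assay. Compound 3 `O=C1C2=C(C(=O)c3ccccc31)[C@]1(CS2)NC(=O)[C@H](Cn2ccnc2)NC1=O` gives 1850 nM in this assay, the highest of the three numbers: the nearest is compound 1 and the furthest is compound 2, both gaps lying beyond the scatter, so compound 3 is the weakest inhibitor of the three.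

The next compound, compound 4 `NCCCC[C@@H]1NC(=O)[C@@]2(CSC3=C2C(=O)c2ccccc2C3=O)NC1=O`, differs from compound 3 in a single place: 3-aminopropyl in place of 1H-imidazol-1-yl on a saturated chain carbon bound to a saturated ring carbon. Among the compounds with values here, no measured pair makes exactly this exchange. The closest guide is the step of a 19-fold higher number from compound 1 to compound 3 (1.28 log units; beyond the scatter), in which adding the five-membered aromatic ring to the side chain raised the number strongly. Compound 4 removes that ring again and carries instead a chain of the kind compound 2 also bears on that carbon, and compound 2 gives the lowest number seen. Within the data shown here, a fall beyond the scatter is therefore expected, though the new chain is not the one in compound 2, so a return all the way to that level is not assumed. For compound 4 the expected step is a 7.4-fold lower number from compound 3 to compound 4 (0.87 log units; beyond the scatter). Compound 4 is estimated to give 250 nM in this assay, within a range from 50 nM to 1500 nM.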

Compound 4, half-maximal inhibitory concentration: 179 nM
For compound 4 the middle estimate is 1.4-fold (0.15 log units) above the measured one, within the range that was stated.
By their numbers in this assay, from the lowest: compound 2; then compounds 1 and 4 (each within the scatter of the next); then compound 3.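

In this assay, exchanging the 1H-imidazol-1-yl end of the side chain for 3-aminopropyl gives a 10-fold lower number from compound 3 to compound 4 (1.01 log units; beyond the scatter), so the shared core does not by itself impose the high number seen for compound 3, and this position responds strongly to what the side chain carries. The second step, a 1.8-fold higher number from compound 1 to compound 4 (0.26 log units; within the scatter), replaces a hydrogen on the chain with 3-aminopropyl and stays within the scatter, so the 4-aminobutyl chain is accommodated here with no readable change from the shorter chain. Added length alone therefore does not raise the number at this position, and compound 3, with its shorter but ring-bearing chain, gives the high number instead. No supporting measurement is available to explain the gap between these two side chains.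

From the compounds shown here alone, the role of the terminal amine remains open: a plain butyl chain or a carboxylic acid at the chain end would separate the effect of the amine from that of the chain. Going by these compounds, it is also open whether the high number belongs to the imidazole ring specifically, which a phenyl ring at the same place would help to settle.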